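Chloro to Hydroxy: Estimating Compound 3

This account rests on a few compounds, and the source may have more. Where it says the series, first, only, none or still open, it means among the compounds named here.

Compound 1, `O=C(N/N=C/c1cccc(Cl)c1)c1cnccn1`: 100%
Compound 2, `O=C(N/N=C/c1ccc(Cl)cc1)c1cnccn1`: 56%

Both compounds were tested in an ADME assay on J774 cells (Mus musculus) for cytotoxicity, read by MTT assay, with a stated time of 48 h, tested at 150 ug/mL; a lower number here means a stronger effect, a higher number a weaker effect of the compound at the concentration tested. Compound 1 gives 100%, the higher of the two numbers, so at the tested concentration it leaves the cells essentially untouched. Compound 2 gives 56%, a number well beyond the scatter below that of compound 1, so the two values do differ. Compound 3, `O=C(N/N=C/c1cccc(O)c1)c1cnccn1`, has not yet been measured in this assay. It differs from compound 1 in one place: hydroxy in place of chloro on an aromatic carbon. Among the compounds with values here, no measured pair shows the effect of this exact exchange, so the direction is open. A change of this kind in the outer group is expected to shift the read-out only modestly, if at all, and the step of a number 15 percentage points lower from compound 1 to compound 3 (beyond the scatter) is estimated to be small, most likely downward or none beyond the scatter. Compound 3 is therefore expected to give about 85%, between 55% and 100%.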

Compound 3, a percentage reported as activity, at one concentration (the size of the read-out at that concentration, not a potency): 88%
Compound 3: middle estimate off by 3 percentage points, on the low side; the measured number falls inside the stated range.
By their numbers in this assay, from the lowest: compound 2; then compound 3; then compound 1.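

In this assay, the exchange of chloro for hydroxy on this aromatic carbon, meta to a large group, now has a measured effect: there is a number 12 percentage points lower from compound 1 to compound 3 (beyond the scatter). The step is modest, so this position accepts a group that brings a hydrogen-bond donor and a hydrogen-bond acceptor, while compound 3 stays at 88%. Compound 2 gives 56% but differs from compound 3 in more than one place, so the two are not compared further here. Nothing among the data shown explains the direction or the size of this step.

The compounds shown leave open how an amine or a carboxylic acid would read at this same place. They also leave open whether hydroxy would give a similar step at the position that carries the chloro in compound 2.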